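This account rests on a few compounds, and the source may have more. Where it says the series, first, only, none or still open, it means among the compounds named here.

In a functional assay on HL-60 cells (Homo sapiens) for cytotoxicity, read by luminescence and CellTiter-Glo, with a stated time of 3 days (a lower number here means a stronger inhibitor, a higher number a weaker inhibitor), compound 1 (`N#Cc1ccc(NC(=O)c2cc(-c3cccnc3)ccc2O)cc1`) gives 7960 nM while compound 2 (`N#Cc1ccc(NC(=O)c2ccccc2O)cc1`) gives 4620 nM and compound 3 (`Cc1ccc(O)c(C(=O)Nc2ccc(C#N)cc2)c1`) gives 3920 nM on the same read-out. Among the compounds with values here, compound 3 stands level with the hydrogen analogue within the scatter (a 1.2-fold lower number from compound 2 to compound 3 (0.07 log units; within the scatter)), and its only step beyond the scatter is modest (a 2.0-fold lower number from compound 1 to compound 3 (0.31 log units; beyond the scatter)). Compound 4 (`N#Cc1ccc(NC(=O)c2cc(Br)ccc2O)cc1`) has bromo in place of methyl on an aromatic carbon, para to a hydroxy group. Within the data shown here, no measured step introduces bromo, so the evidence is indirect. The measured steps also change a group on an aromatic carbon, and even replacing pyridin-3-yl with hydrogen stays within the scatter (a 1.7-fold lower number from compound 1 to compound 2 (0.24 log units; within the scatter)). Methyl in place of hydrogen is smaller still (a 1.2-fold lower number from compound 2 to compound 3 (0.07 log units; within the scatter)). On these three compounds, no step beyond the scatter is expected in this assay for this exchange of one heavy atom. The expected change is slight (a 1.1-fold lower number from compound 3 to compound 4 (0.05 log units; within the scatter)). For compound 4 the estimated value is 3500 nM (expected range 1500 nM to 7000 nM).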

Compound 4, half-maximal inhibitory concentration: 620 nM
The estimate for compound 4 lay 5.6-fold (0.75 log units) above the measured number; the whole stated range lies above it.
By their numbers in this assay, from the lowest: compound 4; then compounds 3, 2 and 1 (each within the scatter of the next, the first and the last beyond it).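

In this assay, the position para to a hydroxy group responds more strongly than the earlier exchanges there suggested: with one heavy atom for one heavy atom, bromo in place of methyl gives a step beyond the scatter (a 6.3-fold lower number from compound 3 to compound 4 (0.80 log units; beyond the scatter)), whereas methyl in place of hydrogen stayed within it. Bromo also stands apart from the hydrogen analogue (a 7.5-fold lower number from compound 2 to compound 4 (0.87 log units; beyond the scatter)) and from the pyridin-3-yl analogue (a 13-fold lower number from compound 1 to compound 4 (1.11 log units; beyond the scatter)), the last step being large, so among these four compounds only bromo separates clearly from the rest at this position. The data shown offer no measurement that would explain this difference.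

Going by these compounds, whether the lower number is particular to bromo or extends to chloro, iodo, trifluoromethyl or an amine at this position remains open. Also open, on these data alone, is whether the step from methyl to bromo carries over to other substituents on the shared core.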